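From compound 3 to compound 4: one added fluoro

The source may report more compounds than this note shows. Statements on the series, on what has been measured and on what is new or still open speak of the compounds shown alone.

Values in an ADME assay on HOS cells (Homo sapiens) for cytotoxicity; a higher number here means a weaker inhibitor, a lower number a stronger inhibitor:
Compound 1 `O=C1c2ccc(O)c(O)c2C(=O)N1Cc1ccc(F)cc1`: "not determined" (no result reported)
Compound 2 `O=C1c2ccc(O)c(O)c2C(=O)N1Cc1cccc(Cl)c1`: 13300 nM
Compound 3 `O=C1c2ccc(O)c(O)c2C(=O)N1Cc1ccc(F)c(Cl)c1`: 9540 nM

Only two of these compounds have a number, since compound 1 has no result. Compound 3 gives 9540 nM and compound 2 gives 13300 nM, and these two numbers lie within the scatter of each other. The next compound is compound 4 `O=C1c2ccc(O)c(O)c2C(=O)N1Cc1cc(Cl)c(F)cc1F`, which carries a single change from compound 3: fluoro in place of hydrogen on an aromatic carbon. This is fluoro in place of hydrogen on an aromatic carbon, ortho to a large group, meta to a fluoro group and para to a chloro group.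

Among the measured compounds shown here, only one measured step is of the same kind: a 1.4-fold lower number from compound 2 to compound 3 (0.14 log units; within the scatter). That step stayed within the scatter, and it put its fluoro at a different place on the ring, so it is thin evidence. No shift beyond the scatter is expected in this assay. The expected change is a 1.1-fold lower number from compound 3 to compound 4 (0.03 log units; within the scatter). For compound 4 the estimated value is 9000 nM, with an expected range of 4000 nM to 20000 nM.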

Compound 4, half-maximal inhibitory concentration: 13700 nM
Compound 4: middle estimate off by 1.5-fold (0.18 log units), on the low side; the measured number falls inside the stated range.
By their numbers in this assay, from the lowest: compounds 3, 2 and 4 (each within the scatter of the next).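

In this assay fluoro on the aromatic carbon ortho to a large group, meta to a fluoro group and para to a chloro group gives a 1.4-fold higher number from compound 3 to compound 4 (0.16 log units; within the scatter) and so shows that this position accepts the added atom without a clear shift. Among the compounds shown here, the one earlier step of this kind gives a 1.4-fold lower number from compound 2 to compound 3 (0.14 log units; within the scatter) with its fluoro at a different place on the ring, so the same change has now been seen at two places, neither moving the number beyond the usual scatter. No measurement shown offers a reason for these close readings.

Every compound shown carries only chloro or fluoro on this ring, so the effect of a methoxy group, a nitrile or an amine at this position remains open. Also open, going by these compounds, is whether a carboxylic acid on the shared core would move the number beyond the scatter.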